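The source may hold more compounds than are shown below. What is called first, only, known or untested is meant among the compounds shown, and "the series" means these compounds.

Working notes on the series in a functional assay on KB cells (Homo sapiens) for cytotoxicity; on this read-out higher numbers stand for an effect only at larger amounts of compound and lower numbers for an effect already at smaller amounts.

Compound 1 `CCC[C@@H](OC(C)=O)C1=C(Br)/C(=C/Br)OC1=O` carries an acetoxy on the saturated chain carbon bound to a double-bonded ring carbon and a saturated chain carbon; in this assay compound 1 gives 2.1 ug/mL. Compound 2 `CCCCC1=C(Br)C(OC)(C(Br)Br)OC1=O` has a different core arrangement and in this assay compound 2 gives 10.5 ug/mL. Compound 3 `CCCCC1=C(Br)/C(=C/Br)OC1=O` lacks the acetoxy. For compound 3 this assay reports only a limit, > 20 ug/mL, which is the limit of > 20 ug/mL in this assay, at which 1 of the 3 values shown sits, and not a number. Among the compounds with values here, the one step that bears on the change at hand is an at least 9.5-fold higher number from compound 1 to compound 3 (0.97 log units; beyond the scatter), so compound 3 stands at the weak end of what has been measured.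

Compound 4 `CCC[C@@H](O)C1=C(Br)/C(=C/Br)OC1=O` differs from compound 3 as follows: hydroxy in place of hydrogen on a saturated chain carbon bound to a double-bonded ring carbon and a saturated chain carbon. The hydroxy restores an oxygen at the place where compound 1 carries the acetoxy, so a move back toward compound 1 is expected, with a lower number in this assay. The expected step is an at least 4.0-fold lower number from compound 3 to compound 4 (0.60 log units; beyond the scatter), though with compound 3 known only as a limit its true size is uncertain. Compound 4 is therefore expected to give about 5 ug/mL, between 1.5 ug/mL and 20 ug/mL.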

Compound 4, concentration for half-maximal effect: 3.4 ug/mL
The estimate for compound 4 lay 1.5-fold (0.17 log units) above the measured number; measured number inside the range.
By their numbers in this assay, from the lowest: compounds 1 and 4 (each within the scatter of the next); then compound 2. At a limit, above all of these: compound 3.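

On the saturated chain carbon bound to a double-bonded ring carbon and a saturated chain carbon, hydroxy in place of hydrogen alone gives, in this assay, an at least 5.8-fold lower number from compound 3 to compound 4 (0.76 log units; beyond the scatter). The acetyl on that oxygen is not needed to keep the effect: removing it gives a 1.6-fold higher number from compound 1 to compound 4 (0.21 log units; within the scatter), so compound 1 and compound 4 cannot be told apart in this read-out. The true size of the gain from hydroxy stays open-ended, since compound 3 is known only as a limit and not as a number: the limit of > 20 ug/mL in this assay, at which 1 of the 4 values shown sits.

The compounds shown leave open whether oxygen is specifically required at this place, or whether an amine or a methoxy there would serve equally. On these data alone, how the opposite configuration at this chain carbon behaves also remains open.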